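The source may hold more compounds than are shown below. What is called first, only, known or untested is meant among the compounds shown, and "the series" means these compounds.

Measured so far in a functional assay on CAKI-1 cells (Homo sapiens) for cytotoxicity, read by sulforhodamine B assay, with a stated time of 48 h; on this read-out lower numbers stand for stronger inhibition of growth and higher numbers for weaker inhibition of growth:
- compound 1 `ClCc1ccc(Cn2cnc3c(Cl)ncnc32)cc1`: 640 nM
- compound 2 `ClCc1ccccc1Cn1cnc2c(Cl)ncnc21`: 4170 nM
- compound 3 `ClCc1ccc(Cn2cnc3nc(Cl)nc(Cl)c32)cc1`: 2750 nM

Compound 1 holds the lowest number of the three in this assay; compound 3 and compound 2 both sit beyond the scatter from it, compound 2 furthest. No two of these compounds differ in only one place, so no single step is resolved here.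

Compound 4 `ClCc1ccc(Cn2cnc3c(Cl)nc(Cl)nc32)cc1` is the next compound, still to be measured. Against compound 1 the change is chloro in place of hydrogen on an aromatic carbon, on the core, between two ring nitrogen atoms. Within the data shown here, no measured pair isolates this change, so the expectation rests on the spread of the three numbers alone. A step of modest size, leaning toward a higher number, is expected a 1.5-fold higher number from compound 1 to compound 4 (0.17 log units; within the scatter). For compound 4 the estimate in this assay is 950 nM, within 350 nM to 2600 nM.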

Compound 4, concentration for total growth inhibition: 21400 nM
Compound 4: middle estimate off by 23-fold (1.35 log units), on the low side; measured number outside the range, above it.
By their numbers in this assay, from the lowest: compound 1; then compounds 3 and 2 (each within the scatter of the next); then compound 4.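

In this assay chloro in place of hydrogen on an aromatic carbon of the core, between two ring nitrogen atoms, gives a 33-fold higher number from compound 1 to compound 4 (1.52 log units; beyond the scatter) as the first single change resolved in the series. This position is therefore sensitive: one added chlorine atom is enough to weaken growth inhibition strongly. Nothing available bears on the origin of this step. Open, going by these compounds, is whether an amine or a methoxy group at this position would behave as chloro does. Also open, on these data alone, is whether any group here keeps the number of compound 1 640 nM.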